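Shortening the ester chain of compound 2

This account rests on a few compounds, and the source may have more. Where it says the series, first, only, none or still open, it means among the compounds named here.

Measured so far in a functional assay on the whole organism with Rattus norvegicus as the target (a lower number here means that less compound is needed, a higher number that more compound is needed for the effect), are two compounds:
Compound 1 (`CCOCCOC(=O)C(=O)Nc1nc(-c2cc(Br)no2)cs1`), 11 mg/kg
Compound 2 (`COCCOC(=O)C(=O)Nc1nc(-c2cc(Br)no2)cs1`), 7 mg/kg

With only these two numbers available, compound 2 stands within the scatter of compound 1, and neither can be ranked above the other. Compound 3 (`CCOC(=O)C(=O)Nc1nc(-c2cc(Br)no2)cs1`) has not yet been measured. It differs from compound 2 by hydrogen in place of methoxy on a saturated chain carbon, two bonds along the chain from an oxygen next to a carbonyl group and so carries hydrogen in place of methoxy on a saturated chain carbon, two bonds along the chain from an oxygen next to a carbonyl group. The 2-methoxyethoxy group thus becomes ethoxy.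

Just one measured step bears on this change, and only indirectly. It alters the same side chain, but it replaces methyl with hydrogen on a saturated chain carbon bound to an oxygen, leaving the methoxy oxygen in place. That step, a 1.6-fold lower number from compound 1 to compound 2 (0.20 log units; within the scatter), gives no reason to expect a large shift or a particular direction in this assay, though loss of the methoxy itself remains untested. The expected step is a 1.1-fold higher number from compound 2 to compound 3 (0.06 log units; within the scatter) and so nothing beyond the scatter. For compound 3 the estimated value is 8 mg/kg, with 4 mg/kg to 18 mg/kg as the expected range.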

Compound 3, dose for half-maximal effect: 12 mg/kg
Compound 3: middle estimate off by 1.5-fold (0.18 log units), on the low side; the measured number falls inside the stated range.
By their numbers in this assay, from the lowest: compounds 2, 1 and 3 (each within the scatter of the next).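

Placed on a saturated chain carbon, two bonds along the chain from an oxygen next to a carbonyl group, hydrogen in place of methoxy gives a 1.7-fold higher number from compound 2 to compound 3 (0.23 log units; within the scatter) in this assay, which is the first direct reading of this change, as the earlier step left the methoxy oxygen in place. At the same place, hydrogen in place of ethoxy gives a 1.1-fold higher number from compound 1 to compound 3 (0.04 log units; within the scatter) in this assay, so that neither the 2-methoxyethoxy group of compound 2 nor the longer ether chain of compound 1 can be told apart from the ethoxy group of compound 3 in this read-out. Nothing available explains these numbers or bears on what the ether oxygen does in the whole animal.

From the compounds shown here alone, all three compounds carry neutral ether or alkyl ester chains, so it stays open whether a different group at this place, such as a dimethylamino group, a hydroxyl or a much longer alkyl chain, would move the number beyond the scatter. It also stays open whether the ester itself matters, since a free carboxylic acid or an amide in its place does not appear among these compounds.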